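Trimming a Methyl Group on Two Amide Scaffolds

A few compounds are considered here, and "the series" means these few. Any claim that something is new, unique, unknown or untested is made for them only; others in the source may bear on it.

Of the compounds shown here, three have been measured in an ADME assay on microsomes from liver (Homo sapiens) for metabolic stability, with a stated time of 0.5 h, tested at 0.5 mg/mL; on this read-out lower numbers stand for a less stable compound and higher numbers for a more stable compound. Compound 1 `CN(C)C(=O)CCNC(=O)c1cc(-c2ccc(F)cc2)no1` gives 87%, compound 3 `CC(CC(=O)N(C)C)NC(=O)c1cc(-c2ccc(F)cc2)no1` gives 91%, and compound 2 `CC(C)C(=O)N1CC2(CC(NC(=O)c3cc(-c4ccccc4)no3)C2)C1` gives 79%. Compound 3 and compound 1 differ in one place, (hydrogen in place of methyl on a saturated chain carbon bound to an amide-type nitrogen and a saturated chain carbon), and the step of a number 4 percentage points lower from compound 3 to compound 1 (within the scatter) stays within the scatter of repeated measurements. The difference between the core of compound 2 and the core of compound 3 is not broken down here.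

Compound 4 `CCC(=O)N1CC2(CC(NC(=O)c3cc(-c4ccccc4)no3)C2)C1` has not yet been measured. It differs from compound 2 by hydrogen in place of methyl on a saturated chain carbon bound to a carbonyl carbon and a saturated chain carbon. Among the measured compounds shown here, this is the same kind of change as the one between compound 3 and compound 1, but the place is not the same: there the saturated chain carbon is bound to an amide-type nitrogen and a saturated chain carbon, here it is bound to a carbonyl carbon and a saturated chain carbon. Because a number 4 percentage points lower from compound 3 to compound 1 (within the scatter) stayed within the scatter, only a small step is expected here as well, a number 1 percentage points lower from compound 2 to compound 4 (within the scatter). Compound 4 is therefore estimated to give 78%, most likely between 65% and 90%.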

Compound 4, percent of the compound remaining: 68%
Beside the measured number, compound 4's estimate is 10 percentage points above it, within the range that was stated.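

In this assay, replacing methyl with hydrogen on the saturated chain carbon bound to a carbonyl carbon and a saturated chain carbon, which turns isopropyl into ethyl, gives a number 11 percentage points lower from compound 2 to compound 4 (beyond the scatter). Set beside the same change on the other core, this step cannot be told apart from the earlier one: the same change on two cores in this assay, a number 4 percentage points lower (within the scatter) from compound 3 to compound 1 and a number 11 percentage points lower (beyond the scatter) from compound 2 to compound 4, 7 percentage points apart, within the scatter of two such steps This means the two cores show no clear difference in how the change behaves, and both numbers fall in the same direction, but it does not show that the step has one fixed size, since only one of the two steps lies beyond the scatter and the methyl sits in a different place on each core.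

The compounds shown leave open how a longer chain, an amine or a carboxylic acid in place of the ethyl would read in this assay. They also leave open whether the step would look the same on a third core.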